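Cyclopropyl aryl variation on the biphenyl amide series

The compounds below may be only part of what the source reports. "The series", "measured", "known", "first", "only" and "open" are said of these compounds alone.

Within the data shown here, compound 3 `CC[C@H](C)[C@H](N)CN(C(=O)[C@@H]1C[C@H]1c1cccc(Cl)c1)c1ccc(-c2ccccc2)cc1` gives 2200 nM in a functional assay for agonist activity at G protein-coupled receptor 88 (Homo sapiens), read by HTRF and cAMP accumulation (a higher number here means that more compound is needed for the effect, a lower number that less compound is needed), the highest of the three numbers measured so far. Compound 2 `CC(C)C[C@@H](N)CN(C(=O)[C@@H]1C[C@H]1c1ccccc1)c1ccc(-c2ccccc2)cc1` gives 1.8 nM and compound 1 `CC(C)C[C@H](N)CN(C(=O)C(C)Cc1ccccc1)c1ccc(-c2ccccc2)cc1` gives 1.2 nM, both far lower than compound 3, beyond the scatter. Compound 4 `CC[C@H](C)[C@H](N)CN(C(=O)[C@@H]1C[C@H]1c1cc(F)ccc1F)c1ccc(-c2ccccc2)cc1` has not been measured. Among the measured compounds shown here, the change from compound 3 is 2,5-difluorophenyl in place of 3-chlorophenyl on a saturated ring carbon; no neighbouring pair isolates a halogen swap on this aryl ring, so its direction rests on no measured step. A small step is expected, a 2.4-fold lower number from compound 3 to compound 4 (0.39 log units; beyond the scatter), towards a lower number but possibly within the scatter. Compound 4 is therefore expected to give about 900 nM, within 90 nM to 9000 nM.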

Compound 4, half-maximal effective concentration: 770 nM
Compound 4: the middle estimate sits 1.2-fold (0.07 log units) above what was measured; low and high end bracket the measured number.
By their numbers in this assay, from the lowest: compounds 1 and 2 (each within the scatter of the next); then compound 4; then compound 3.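

Among these compounds, on the saturated ring carbon of the three-membered ring, 2,5-difluorophenyl in place of 3-chlorophenyl gives the first measured step at this position in this assay: a 2.9-fold lower number from compound 3 to compound 4 (0.46 log units; beyond the scatter). The aryl group here can therefore shift the number beyond the scatter, although this exchange does so only modestly. The step alters both halogen type and halogen count, so it cannot assign the shift to either one alone.

Going by these compounds, a nitrile or methoxy group in place of these halogens on the aryl ring remains open. No available evidence accounts for the step.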